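A tert-butyl swap on sulfur at low growth inhibition

The source may hold more compounds than are shown below. What is called first, only, known or untested is meant among the compounds shown, and "the series" means these compounds.

Compound 1 (`Nc1ccccc1NC(=O)/C=C/c1ccc(CSc2cccc(F)c2)cc1`) gives 6.75% in a functional assay on A-375 cells (Homo sapiens) for inhibition, read by CCK-8 assay, with a stated time of 72 h, tested at 2 uM; a higher number here means more inhibition of growth at the concentration tested, a lower number less inhibition of growth. Compound 2 (`CC(C)(C)c1ccc(SCc2ccc(C(=O)Nc3ccccc3N)cc2)cc1`) gives 2.13%, a number within the scatter of the value for compound 1. Compound 3 (`COC(=O)c1ccccc1SCc1ccc(C(=O)Nc2ccccc2N)cc1`) gives 35.1%, which lies beyond the scatter above compound 1. Compound 1 therefore sits with compound 2 at the low end of this small set, well short of compound 3.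

Compound 4 (`CC(C)(C)c1ccc(SCc2ccc(/C=C/C(=O)Nc3ccccc3N)cc2)cc1`) keeps the rest of compound 1 and changes one group: 4-(tert-butyl)phenyl comes in place of 3-fluorophenyl on a sulfur (4-(tert-butyl)phenyl in place of 3-fluorophenyl on a sulfur). Going by the values given here, no pair of measured compounds differs in one place only, so the size of this step has no direct precedent in the data. The nearest guide is compound 2, which carries the same 4-(tert-butyl)phenyl on a sulfur and gives 2.13%. The high number of compound 3 comes with a different group on the sulfur, one that compound 4 does not carry. The expected step of a number 0.8 percentage points lower from compound 1 to compound 4 (within the scatter) is therefore none beyond the scatter. For compound 4 the estimate is 6%, with an expected range from 0% to 18%.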

Compound 4, percent growth inhibition at one concentration: 38.4%
Compound 4: middle estimate off by 32.4 percentage points, on the low side, outside the stated range (above it).
By their numbers in this assay, from the lowest: compounds 2 and 1 (each within the scatter of the next); then compounds 3 and 4 (each within the scatter of the next).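

In this assay, going by these compounds alone, 4-(tert-butyl)phenyl in place of 3-fluorophenyl on a sulfur gives a number 31.7 percentage points higher from compound 1 to compound 4 (beyond the scatter) and is the first change in this set that can be read in one place, showing that the group on this sulfur can decide whether the number stays low or climbs well beyond the scatter. Compound 2 carries the same 4-(tert-butyl)phenyl on a sulfur and gives 2.13% in this assay, but it also differs from compound 4 elsewhere, so no step can be read between them and the group evidently does not bring a high number in every compound shown. No measurement is at hand that accounts for the size of this step.

With only these two groups at this position, the compounds shown do not separate the gain of the tert-butyl group from the loss of the fluorine or from the shift in where the ring is substituted. On these data alone, an unsubstituted phenyl, a 4-fluorophenyl or a 4-isopropylphenyl on the same sulfur would be needed to tell these apart, and how far the step holds on other cores also stays open.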